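Nitro in place of trifluoromethyl: expected step for compound 4

The compounds below may be only part of what the source reports. "The series", "measured", "known", "first", "only" and "open" are said of these compounds alone.

Of the compounds shown here, three of the shared core have been measured in a functional assay on MDA-MB-231 cells (Homo sapiens) for cytotoxicity, read by MTT assay, with a stated time of 48 h; a lower number here means a stronger inhibitor, a higher number a weaker inhibitor. Compound 1 `O=C(/C=C/c1ccc2c(c1)B(O)OC2)c1ccc(O)cc1` gives 25600 nM. Compound 2 `Nc1ccc(C(=O)/C=C/c2ccc3c(c2)B(O)OC3)cc1` gives 25800 nM. Compound 3 `O=C(/C=C/c1ccc2c(c1)B(O)OC2)c1ccc(C(F)(F)F)cc1` gives 9200 nM, the lowest of the three numbers; its nearest neighbour is compound 1 and its furthest compound 2, both separated from it by a gap beyond the scatter. The measured steps are a 1.0-fold higher number from compound 1 to compound 2 (0.00 log units; within the scatter), a 2.8-fold lower number from compound 1 to compound 3 (0.44 log units; beyond the scatter) and a 2.8-fold lower number from compound 2 to compound 3 (0.45 log units; beyond the scatter).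

Compound 4 `O=C(/C=C/c1ccc2c(c1)B(O)OC2)c1ccc([N+](=O)[O-])cc1` differs from compound 3 by nitro in place of trifluoromethyl on an aromatic carbon. Within the data shown here, no measured step exchanges trifluoromethyl for nitro. Among the measured compounds shown here, the steps that bear on it are the two that bring trifluoromethyl in, a 2.8-fold lower number from compound 1 to compound 3 (0.44 log units; beyond the scatter) and a 2.8-fold lower number from compound 2 to compound 3 (0.45 log units; beyond the scatter), both modest and both towards a lower number, while the step of a 1.0-fold higher number from compound 1 to compound 2 (0.00 log units; within the scatter) shows that an exchange of one group for another on that aromatic carbon can also leave the number unchanged. With trifluoromethyl leaving and no measured guide for nitro, the expected step in this assay is a 1.2-fold higher number from compound 3 to compound 4 (0.08 log units; within the scatter), which is within the scatter. Compound 4 is therefore expected at 11000 nM, with a range from 4000 nM to 30000 nM.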

Compound 4, half-maximal inhibitory concentration: 11200 nM
Beside the measured number, compound 4's estimate is 1.0-fold (0.01 log units) below it; the range from low to high includes it.
By their numbers in this assay, from the lowest: compounds 3 and 4 (each within the scatter of the next); then compounds 1 and 2 (each within the scatter of the next).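

In this assay the exchange of trifluoromethyl for nitro on this aromatic carbon, para to a large group, gives a 1.2-fold higher number from compound 3 to compound 4 (0.09 log units; within the scatter), so a group without hydrogen-bond acceptors and a group with them sit within the scatter of each other at this position. Nitro also stays apart from the two earlier groups, with a 2.3-fold lower number from compound 2 to compound 4 (0.36 log units; beyond the scatter) and a 2.3-fold lower number from compound 1 to compound 4 (0.36 log units; beyond the scatter), so the lower numbers no longer rest on trifluoromethyl alone, and the four compounds now form two pairs, trifluoromethyl with nitro and hydroxy with amino. Nothing in hand explains this grouping or says what the two members of each pair have in common.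

On these data alone, whether the pairing reaches further at this position stays open: a nitrile, a carboxylic acid, a chlorine or a plain methyl could fall with either pair or with neither. Also open, as far as these compounds go, is where a dimethylamino group or a longer alkoxy chain on the same carbon would fall, and whether the two pairs persist when the same groups stand elsewhere on that ring.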